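This account rests on a few compounds, and the source may have more. Where it says the series, first, only, none or still open, it means among the compounds named here.

Working notes on the series. In a functional assay for agonist activity at G protein-coupled receptor 88 (Homo sapiens), read by HTRF and cAMP accumulation (a lower number here means that less compound is needed, a higher number that more compound is needed for the effect), compound 1 `CC[C@H](C)[C@H](N)CN(C(=O)[C@@H]1C[C@H]1c1ccccc1)c1ccc(-c2ccccc2)cc1` gives 230 nM; 800 nM (2 entries); the spread across its repeat entries is seen in the several entries of compound 1 in this assay, 230 nM; 800 nM (2 entries). Among the compounds with values here, compound 2 `CC[C@H](C)[C@H](N)CN(C(=O)[C@@H]1C[C@H]1c1ncccn1)c1ccc(-c2ccccc2)cc1` gives 130 nM in this assay, the only number it has, with one further entry that carries no single number. Compound 3 `CC[C@H](C)[C@H](N)CN(C(=O)[C@@H]1C[C@H]1c1nc(C)c(C)s1)c1ccc(-c2ccccc2)cc1` is not yet measured; it carries 4,5-dimethyl-1,3-thiazol-2-yl in place of pyrimidin-2-yl on a saturated ring carbon, 4,5-dimethyl-1,3-thiazol-2-yl in place of pyrimidin-2-yl on a saturated ring carbon. Within the data shown here, no measured pair shows this change, so the expected step in this assay is a 1.5-fold higher number from compound 2 to compound 3 (0.19 log units; within the scatter), none beyond the scatter. Compound 3 is estimated at 200 nM, within 60 nM to 700 nM.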

Compound 3, half-maximal effective concentration: 3600 nM
The estimate for compound 3 lay 18-fold (1.26 log units) below the measured number; measured number above the stated range.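

In this assay, the saturated ring carbon of the three-membered ring does not treat all aromatic groups alike: 4,5-dimethyl-1,3-thiazol-2-yl in place of pyrimidin-2-yl gives a 28-fold higher number from compound 2 to compound 3 (1.44 log units; beyond the scatter). Within the data shown here, this is the first step readable at this position, and it shows that the group there can strongly change the number. The step is larger than the spread between repeat entries: the several entries of compound 1 in this assay, 230 nM; 800 nM (2 entries)

The compounds shown do not separate the two methyl groups from the five-membered ring itself. As far as these compounds go, how an unsubstituted 1,3-thiazol-2-yl group would read here stays open.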